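From nitrile to hydroxyethyl amide: cytotoxicity outlook

This account rests on a few compounds, and the source may have more. Where it says the series, first, only, none or still open, it means among the compounds named here.

Compound 3 `N#Cc1c(Cn2c(=O)n(C3CC3)c3ccncc32)nc2cc(Cl)ccn12` is the only one of the three measured compounds to yield a number in an ADME assay on HEp-2 cells (Homo sapiens) for cytotoxicity, read by CCK-8 assay, with a stated time of 6 days; on this read-out higher numbers stand for lower toxicity in this test and lower numbers for higher toxicity in this test: compound 3 gives 22500 nM. Compound 1 `O=c1n(Cc2nc3ccccn3c2CCCCO)c2cnccc2n1C1CC1` returns only a limit in this assay, > 100000 nM. Compound 2 `O=c1n(Cc2nc3cc(C(F)(F)F)ccn3c2CCCCO)c2cnccc2n1C1CC1` likewise returns a limit, > 100000 nM. Among the measured compounds shown here, because of the limit of > 100000 nM in this assay, at which 2 of the 3 values shown sit, the single step between measured compounds, a step that the two limits leave unreadable from compound 1 to compound 2, offers no size to lean on, and compound 3 stands alone as the one readable point.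

Compound 4 `O=C(CCc1c(Cn2c(=O)n(C3CC3)c3ccncc32)nc2cc(Cl)ccn12)NCCO` differs from compound 3 by 2-((2-hydroxyethyl)carbamoyl)ethyl in place of cyano on an aromatic carbon. For the measured compounds named here, no measured step touches this kind of change, so the expectation rests only on where compound 3 sits and on the spread of the other values in this assay. Compound 4 is expected to land near 60000 nM, within a range from 20000 nM to 150000 nM. That corresponds to an expected step of a 2.7-fold higher number from compound 3 to compound 4 (0.43 log units; beyond the scatter), a movement toward lower toxicity that may well end as a limit rather than a number.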

Compound 4, half-maximal cytotoxic concentration: > 100000 nM
Compound 4 ended at the assay's limit; the forecaster's own chance of this, stated with the estimate: 45%; at least 1.6-fold (0.22 log units) between middle value and limit.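

Where the earlier step between two limits cannot be read, putting 2-((2-hydroxyethyl)carbamoyl)ethyl in place of cyano on this aromatic carbon gives an at least 4.4-fold higher number from compound 3 to compound 4 (0.64 log units; beyond the scatter) in this assay, a move toward lower toxicity in this test. The result for compound 4 is a limit of the assay and not a number. As far as these compounds go, the step is therefore only a lower bound, and its full size stays unknown because of one feature of these data: the limit of > 100000 nM in this assay, at which 3 of the 4 values shown sit.

The compounds shown leave open which part of the 2-((2-hydroxyethyl)carbamoyl)ethyl chain goes with this step, and whether a carboxylic acid or an amine on this aromatic carbon would also reach the limit. Compound 3 is also the only compound shown that carries cyano, so whether cyano itself goes with its readable number stays open.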